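Piperidine simplification on a triazine anilinonitrile series

The compounds below may be only part of what the source reports. "The series", "measured", "known", "first", "only" and "open" are said of these compounds alone.

Compound 1 `CC1CC(C)CN(c2nc(Nc3ccc(C#N)c(C(F)(F)F)c3)nc(Oc3ccnc4ccccc34)n2)C1` carries a 3,5-dimethylpiperidin-1-yl group on the shared core. In a functional assay on DU-145 cells (Homo sapiens) for cytotoxicity, read by sulforhodamine B assay, with a stated time of 48 h (on this read-out lower numbers stand for higher toxicity in this test and higher numbers for lower toxicity in this test), compound 1 reaches only the limit of the test, > 100000 nM. Two further members sit at the same limit. Compound 2 `N#Cc1ccc(Nc2nc(Oc3ccnc4ccccc34)nc(N3CCN(c4cccc(C(F)(F)F)c4)CC3)n2)cc1C(F)(F)F` gives in this assay > 100000 nM, a limit rather than a number. Compound 3 `COc1ccc(CN2CCN(c3nc(Nc4ccc(C#N)c(C(F)(F)F)c4)nc(Oc4ccnc5ccccc45)n3)CC2)c(OC)c1OC` gives in this assay > 100000 nM, again a limit. All three measured values therefore stand together: the limit of > 100000 nM in this assay, at which 3 of the 3 values shown sit. For the measured compounds named here, no pair of measured compounds differs in a single place, so no measured step is available, and compound 1 cannot be ranked against compound 2 or compound 3 beyond the shared limit.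

Compound 4 `N#Cc1ccc(Nc2nc(Oc3ccnc4ccccc34)nc(N3CCCCC3)n2)cc1C(F)(F)F` is the unmeasured member. It differs from compound 1 by piperidin-1-yl in place of 3,5-dimethylpiperidin-1-yl on an aromatic carbon. Going by the values given here, nothing among the measured compounds shows a change of this kind moving the read-out off the limit. The step from compound 1 to compound 4 in this assay is expected to be none beyond the scatter, with the read-out most likely again reported as a limit. The step implied by this estimate is a step that the limit leaves unreadable from compound 1 to compound 4. Compound 4 is expected to give 150000 nM in this assay, within a range from 40000 nM to 600000 nM.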

Compound 4, concentration lethal to 50% of the cells: > 100000 nM
Compound 4 ended at the assay's limit; the forecaster's own chance of this, stated with the estimate: 85%; the middle value is on the limit's open side.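

No new step can be read from compound 1 to compound 4, as both sit at a limit of this assay and neither gives a number: the limit of > 100000 nM in this assay, at which 4 of the 4 values shown sit.

The compounds shown leave open whether any change on the shared core brings the read-out off this limit, and how large the piperidine change would be on a readable scale.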